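Working notes: compound 2 to compound 3

The source may hold more compounds than are shown below. What is called first, only, known or untested is meant among the compounds shown, and "the series" means these compounds.

Values in a functional assay on CCRF-CEM cells (Homo sapiens) for antiproliferative activity; on this read-out higher numbers stand for weaker inhibition and lower numbers for stronger inhibition:
- compound 1 `COc1cc(C(=O)c2sc(-c3ccc(I)cc3)cc2N)cc(OC)c1OC`: 150 nM
- compound 2 `COc1cc(C(=O)c2sc(-c3ccsc3)cc2N)cc(OC)c1OC`: 9.6 nM
- compound 3 `COc1cc(C(=O)c2sc(-c3ccc(C)cc3)cc2N)cc(OC)c1OC`: not yet measured

Compound 2 holds the lower of the two numbers in this assay, at 9.6 nM. The change to compound 3 is 4-methylphenyl in place of thiophen-3-yl on an aromatic carbon. For the measured compounds named here, the one measured step bearing on it is large and beyond the scatter: a 16-fold lower number from compound 1 to compound 2 (1.19 log units; beyond the scatter), thiophen-3-yl in place of 4-iodophenyl. Compound 3 returns to a substituted phenyl, so a higher number is expected, though the data hold no comparison of 4-methylphenyl with 4-iodophenyl. The expected step is a 4.2-fold higher number from compound 2 to compound 3 (0.62 log units; beyond the scatter), probably smaller than the measured one. Compound 3 is estimated at 40 nM, with an expected range of 10 nM to 150 nM.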

Compound 3, half-maximal inhibitory concentration: 15 nM
The estimate for compound 3 lay 2.7-fold (0.43 log units) above the measured number; the range from low to high includes it.
By their numbers in this assay, from the lowest: compounds 2 and 3 (each within the scatter of the next); then compound 1.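

In this assay, at the aromatic carbon next to the ring sulfur, the change to 4-methylphenyl gives a 1.6-fold higher number from compound 2 to compound 3 (0.19 log units; within the scatter) and so stays level with thiophen-3-yl; the high number of compound 1 therefore does not hold for every six-membered aromatic ring at this position. The group on that ring matters, as methyl in place of iodo gives a 10-fold lower number from compound 1 to compound 3 (1.00 log units; beyond the scatter) and is a clear gain. No evidence bears on the reason for either step.

Open, on these data alone, is where an unsubstituted phenyl, a 4-methoxyphenyl or a 4-chlorophenyl would fall relative to the methyl and iodo compounds. Also open, as far as these compounds go, is whether thiophen-2-yl would match thiophen-3-yl.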